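Methoxy for chloro on the oxindole ring: step from compound 3 to 4

This account rests on a few compounds, and the source may have more. Where it says the series, first, only, none or still open, it means among the compounds named here.

Measured compounds in a functional assay on cells (Melanoma cell, Homo sapiens) for cytotoxicity, with a stated time of 48 h; on this read-out higher numbers stand for weaker inhibition of growth and lower numbers for stronger inhibition of growth:
compound 1 `COc1c(/C=C2/C(=O)Nc3ccccc32)c2ccccc2n1-c1ccccc1`, 1480 nM
compound 2 `COc1cc2c(cc1C)NC(=O)/C2=C/c1c(Cl)n(Cc2cc(OC)c(OC)c(OC)c2)c2cc(C)c(OC)cc12`, 25100 nM
compound 3 `COc1c(/C=C2/C(=O)Nc3ccc(Cl)cc32)c2ccccc2n1-c1ccccc1`, 5620 nM

In this assay compound 3 gives the second highest of the three numbers; compound 1 sits below it by a 3.8-fold higher number from compound 1 to compound 3 (0.58 log units; beyond the scatter), while compound 2 gives the highest number of the set. Compound 4 `COc1ccc2c(c1)/C(=C\c1c(OC)n(-c3ccccc3)c3ccccc13)C(=O)N2` differs from compound 3 by methoxy in place of chloro on an aromatic carbon. Going by the values given here, the only measured step that bears on this position is hydrogen to chloro, a 3.8-fold higher number from compound 1 to compound 3 (0.58 log units; beyond the scatter), a modest rise. Among the compounds with values here, no measured pair shows methoxy against chloro; compound 2 carries methoxy on its oxindole ring but differs from compound 3 in many further places. Compound 4 is therefore expected to land between compound 1 and compound 3, a step of a 1.9-fold lower number from compound 3 to compound 4 (0.27 log units; within the scatter). The estimate for compound 4 is 3000 nM, within 1000 nM to 10000 nM.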

Compound 4, concentration for 50% growth inhibition: 2400 nM
Compound 4: middle estimate off by 1.3-fold (0.10 log units), on the high side, and the stated range covers the measured number.
By their numbers in this assay, from the lowest: compounds 1 and 4 (each within the scatter of the next); then compound 3; then compound 2.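

In this assay, methoxy in place of chloro on this aromatic carbon gives a 2.3-fold lower number from compound 3 to compound 4 (0.37 log units; beyond the scatter), so the rise seen with chloro does not extend to every group placed here. Methoxy in place of hydrogen gives a 1.6-fold higher number from compound 1 to compound 4 (0.21 log units; within the scatter), which leaves the two indistinguishable at this position. No supporting data bear on why chloro stands apart from methoxy and hydrogen. Still open, as far as these compounds go, is how fluoro, an amine or a carboxylic acid on this carbon would compare with chloro and methoxy. Also open, from the compounds shown here alone, is whether the chloro and methoxy difference holds on other cell types.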